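This account rests on a few compounds, and the source may have more. Where it says the series, first, only, none or still open, it means among the compounds named here.

Measured so far:
- compound 1 `Cc1cccc(/C(N)=N/NC(=S)N2CCSCC2)n1`, 80.7%
- compound 2 `Cc1ccnc(/C(N)=N/NC(=S)N2CCN(c3ccccn3)CC2)c1`, 75.5%
- compound 3 `N/C(=N\NC(=S)N1CCSCC1)c1ccccn1`, 80.8%

All three numbers come from a functional assay on A-431 cells (Homo sapiens) for cytotoxicity, read by MTT assay, with a stated time of 72 h, tested at 100 uM; on this read-out higher numbers stand for more inhibition of growth at the one concentration tested and lower numbers for less inhibition of growth. For the measured compounds named here, on this read-out compound 1 stands second highest of three; its nearest neighbour is compound 3, and the one step that is computed, a number 0.1 percentage points higher from compound 1 to compound 3 (within the scatter), lies within the scatter. Going by the values given here, compound 2 sits lowest, but it differs from compound 1 in two places at once, so no single step is drawn between them; their two values are also within the scatter of each other.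

The next compound, compound 4 `Cc1cccc(/C(N)=N/NC(=S)N2CCCC2)n1`, is reached from compound 1 by pyrrolidin-1-yl in place of thiomorpholin-4-yl on a thiocarbonyl carbon. Among the compounds with values here, no measured step changes this part of the molecule on its own, so nothing among the measured steps bears directly on it; the only change of the ring on the thiocarbonyl carbon, in compound 2, is mixed with a second change and stays within the scatter. The expectation for this assay is therefore no step beyond the scatter, with an estimated step of a number 2.7 percentage points lower from compound 1 to compound 4 (within the scatter).

Compound 4 is estimated at 78% in this assay, with a range from 64% to 88%.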

Compound 4, percent growth inhibition at one concentration: 86.8%
For compound 4 the middle estimate is 8.8 percentage points below the measured one, within the range that was stated.
By their numbers in this assay, from the lowest: compounds 2, 1, 3 and 4 (each within the scatter of the next, the first and the last beyond it).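

For the compounds shown here, the ring on the thiocarbonyl carbon is now changed on its own for the first time: in this assay, the step is a number 6.1 percentage points higher from compound 1 to compound 4 (within the scatter), with pyrrolidin-1-yl in place of thiomorpholin-4-yl. This exchange alters the ring size and removes the ring sulfur, yet the step stays within the scatter, so this pair shows no measurable dependence of the read-out on that difference. No available evidence bears on this result.

From the compounds shown here alone, whether the same holds for piperidin-1-yl, morpholin-4-yl or an open-chain diethylamino group on the thiocarbonyl carbon remains open. Also open, going by these compounds, is whether pyrrolidin-1-yl gives the same result without the methyl on the aromatic carbon, and a single-concentration read-out cannot show whether potency differs within the pair.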